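Vero cytotoxicity across benzofuran pyrazolines: a positional isomer

The source may report more compounds than this note shows. Statements on the series, on what has been measured and on what is new or still open speak of the compounds shown alone.

Compound 2 `CCn1cc(C(=O)N2N=C(c3cc4ccccc4o3)CC2c2cccc([N+](=O)[O-])c2)c(=O)c2ccc(C)nc21` was run in an ADME assay on Vero cells (Chlorocebus sabaeus) for cytotoxicity, read by MTT assay, with a stated time of 72 h; a higher number here means a weaker inhibitor, a lower number a stronger inhibitor. Here compound 2 gives > 164000 nM, a limit of the assay rather than a number, resting at the limit of > 164000 nM in this assay, at which 1 of the 2 values shown sits. Compound 1 `O=C(c1ccncc1)N1N=C(c2cc3ccccc3o2)CC1c1ccccc1Cl` is the other member shown. In this assay compound 1 gives > 210000 nM, again a limit and not a number, resting at the limit of > 210000 nM in this assay, at which 1 of the 2 values shown sits. Compound 3 `CCn1cc(C(=O)N2N=C(c3cc4ccccc4o3)CC2c2ccccc2[N+](=O)[O-])c(=O)c2ccc(C)nc21` is not yet measured; it differs from compound 2 by 2-nitrophenyl in place of 3-nitrophenyl on a saturated ring carbon. With both shown values resting at limits, nothing beyond the scatter is expected in this assay. Compound 3 is expected to show a step that the limit leaves unreadable from compound 2 to compound 3. For compound 3 the estimate is 200000 nM, within 100000 nM to 600000 nM, most likely reported once more as a limit.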

Compound 3, half-maximal inhibitory concentration: > 85400 nM
Compound 3: a limit, no number; the forecaster's own chance of this, stated with the estimate: 85%; the middle value does not contradict the limit.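

Compound 2 and compound 3 both stand as limits of the assay, not numbers, and the step from 3-nitrophenyl to 2-nitrophenyl cannot be read. The compounds shown leave open whether that change alters the read-out in this assay at all.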